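This account rests on a few compounds, and the source may have more. Where it says the series, first, only, none or still open, it means among the compounds named here.

Working notes on the series. Compound 1 `Cn1nc(COc2cc(F)cc(F)c2)c2c1CCN(C(=S)Nc1ccc(Cl)cc1)C2` carries 4-chlorophenyl on an amide-type nitrogen. In an assay on cells for inhibition of Pendrin (Mus musculus), read by fluorescence, with a stated time of 10 min (on this read-out lower numbers stand for stronger inhibition and higher numbers for weaker inhibition), compound 1 gives only a limit, > 10000 nM. Compound 2 `Cn1nc(COc2cc(F)cc(F)c2)c2c1CCN(C(=S)NC1CCCCC1)C2` carries cyclohexyl in place of 4-chlorophenyl on that amide-type nitrogen. In this assay compound 2 also gives only a limit, > 10000 nM. Compound 3 `Cn1nc(COc2cc(F)cc(F)c2)c2c1CCN(S(=O)(=O)c1ccc(Cl)cc1)C2` carries the (4-chlorophenyl)sulfonyl group on an amine nitrogen in a ring. In this assay compound 3 likewise gives only a limit, > 10000 nM. The steps a step that the two limits leave unreadable from compound 1 to compound 2, a step that the two limits leave unreadable from compound 1 to compound 3 and a step that the two limits leave unreadable from compound 2 to compound 3 cannot be sized, since (the limit of > 10000 nM in this assay, at which 3 of the 3 values shown sit).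

Compound 4 `CCN(CC)S(=O)(=O)N1CCc2c(c(COc3cc(F)cc(F)c3)nn2C)C1` follows from compound 3 by diethylamino in place of 4-chlorophenyl on a sulfonyl sulfur. Among the measured compounds shown here, no measured step touches the sulfonyl sulfur itself; the steps that exist, all unreadable, show only that neither the two substituents on the amide-type nitrogen nor the change to the sulfonyl group brought any compound inside the measurable range of this assay. The expectation for compound 4 in this assay is therefore that it again sits at the limit, and the step that the limit leaves unreadable from compound 3 to compound 4 is estimated as nothing that could be read. Compound 4 is estimated at 15000 nM, with a range from 5000 nM to 50000 nM.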

Compound 4, half-maximal inhibitory concentration: > 10000 nM
Compound 4 ended at the assay's limit; the forecaster's own chance of this, stated with the estimate: 85%; the middle value lies beyond the limit too.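

Compound 4 yields no readable step against compound 1, compound 2 or compound 3, because all four compounds give only the same limit: the limit of > 10000 nM in this assay, at which 4 of the 4 values shown sit.

The compounds shown leave open how far each lies beyond that limit, and which change to the shared core, if any, would bring a value inside the measurable range of this assay.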